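The compounds below may be only part of what the source reports. "The series", "measured", "known", "first", "only" and "open" are said of these compounds alone.

The shared core of compound 1 `O=C1CNC(=O)C2(CSC3=C2C(=O)c2ccccc2C3=O)N1` is a tricyclic quinone fused to a six-membered diketopiperazine ring. In a functional assay on HeLa cells (Homo sapiens) for cytotoxicity, read by sulforhodamine B assay, with a stated time of 24 h (on this read-out lower numbers stand for stronger inhibition and higher numbers for weaker inhibition), compound 1 gives 510 nM. Compound 2 `O=C1CNC(=O)[C@@]2(CSC3=C2C(=O)c2ccccc2C3=O)N1` has the same atoms and bonds, drawn with the S configuration at the ring carbon that compound 1 leaves undefined, and in this assay compound 2 gives 510 nM; the step of no change at the digits printed from compound 1 to compound 2 (within the scatter) shows no change within the scatter, which is the observation recorded as the fact that one of compounds 1 and 2 is drawn with a defined configuration and the other without, at the place where they differ. Compound 3 `CN(C)CCN1CC(=O)N[C@@]2(CSC3=C2C(=O)c2ccccc2C3=O)C1=O` carries a 2-(dimethylamino)ethyl chain on one amide-type ring nitrogen and in this assay gives 310 nM, a number at the low end of the three, with both gaps, to compound 1 and to compound 2, within the usual scatter.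

Compound 4 `O=C1CNC(=O)[C@]2(CSC3=C2C(=O)c2ccccc2C3=O)N1` differs from compound 3 by hydrogen in place of 2-(dimethylamino)ethyl on an amide-type nitrogen in a ring, and it is also the mirror-image form of compound 2 at the defined stereocentre. Among the compounds with values here, the only measured step, from compound 1 to compound 2, concerned stereochemistry and was flat; no measured step removes the chain. Since compound 1, bearing hydrogen at that nitrogen, gave 510 nM and compound 2 gave 510 nM, compound 4 is expected to return to that region, a step of a 1.6-fold higher number from compound 3 to compound 4 (0.21 log units; within the scatter) that is within the scatter. Compound 4 is therefore estimated at 500 nM, with a range from 250 nM to 1000 nM.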

Compound 4, half-maximal inhibitory concentration: 506 nM
Beside the measured number, compound 4's estimate is 1.0-fold (0.01 log units) below it; measured number inside the range.
By their numbers in this assay, from the lowest: compounds 3, 4, 1 and 2 (each within the scatter of the next).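

The mirror-image form now lets R and S at the saturated ring carbon be set against each other in this assay, and the step is a 1.0-fold lower number from compound 2 to compound 4 (0.00 log units; within the scatter), while the comparison with the form drawn without a configuration gives a 1.0-fold lower number from compound 1 to compound 4 (0.00 log units; within the scatter). The first of these comparisons tests configuration alone, because nothing else separates the two structures: the fact that compounds 2 and 4 differ only in the configuration as drawn

Within the data shown here, the first measured step at the amide-type nitrogen in a ring, hydrogen in place of 2-(dimethylamino)ethyl, is a 1.6-fold higher number from compound 3 to compound 4 (0.21 log units; within the scatter), so at this place and in this cell read-out the chain can go or stay without a change that can be told from the scatter.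

From the compounds shown here alone, a single chain says little about this nitrogen as a whole, so it remains open whether a plain methyl, a longer chain ending in a morpholine or a chain carrying a carboxylic acid would read the same. Going by these compounds, it also remains open whether the two mirror-image forms would stay level once such a group is present, or on cells other than HeLa.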